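Adding a Second Methoxy to the Aryl Ketone End

The source may report more compounds than this note shows. Statements on the series, on what has been measured and on what is new or still open speak of the compounds shown alone.

Compound 1 `COc1cc(-c2cc(/C=C/C(=O)c3ccc(N)cc3)[nH]n2)cc(OC)c1OC`: 92%
Compound 2 `COc1ccc(C(=O)/C=C/c2cc(-c3cc(OC)c(OC)c(OC)c3)n[nH]2)cc1`: 87%

Among the compounds with values here, in a functional assay on NCI-H522 cells (Homo sapiens) for cytotoxicity, read by sulforhodamine B assay, with a stated time of 48 h, tested at 0.1 uM (a lower number here means a stronger effect, a higher number a weaker effect of the compound at the concentration tested), compound 2 gives 87%, the lowest of the two numbers, with compound 1 as its only neighbour, a step of a number 5 percentage points lower from compound 1 to compound 2 (within the scatter). Compound 3 `COc1ccc(C(=O)/C=C/c2cc(-c3cc(OC)c(OC)c(OC)c3)n[nH]2)cc1OC` differs from compound 2 by methoxy in place of hydrogen on an aromatic carbon, which turns a 4-methoxyphenyl into a 3,4-dimethoxyphenyl. Within the data shown here, no measured step covers that change; the one known step, a number 5 percentage points lower from compound 1 to compound 2 (within the scatter), concerns a different group and stayed within the scatter. The expected step is therefore none beyond the scatter, a number 2 percentage points lower from compound 2 to compound 3 (within the scatter). Compound 3 is expected to give 85%, between 68% and 100%.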

Compound 3, a percentage reported as activity, at one concentration (the size of the read-out at that concentration, not a potency): 91%
The estimate for compound 3 lay 6 percentage points below the measured number; the measured number falls inside the stated range.
By their numbers in this assay, from the lowest: compounds 2, 3 and 1 (each within the scatter of the next).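

In this assay, going from 4-methoxyphenyl to 3,4-dimethoxyphenyl gives a number 4 percentage points higher from compound 2 to compound 3 (within the scatter), so a methoxy at this ring position, ortho to a methoxy group, leaves no readable change. Placing 3,4-dimethoxyphenyl in place of 4-aminophenyl on the carbonyl carbon gives a number 1 percentage points lower from compound 1 to compound 3 (within the scatter), so a change at two ring positions at once also leaves the number within the scatter. Nothing available explains why these numbers stay so close. On these data alone, whether an ethoxy, a hydroxyl or a carboxylic acid at this position would shift the number remains open, as does how these compounds compare at higher concentrations.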